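This account rests on a few compounds, and the source may have more. Where it says the series, first, only, none or still open, it means among the compounds named here.

Working notes on the series.

In an assay on RPMI-8226 cells for antagonist activity at P2X purinoceptor 7 (Homo sapiens), read by calcium flux (on this read-out higher numbers stand for weaker inhibition and lower numbers for stronger inhibition), compound 1 `N#Cc1cn(CCCCN2CCN(C(c3ccccc3)c3ccccc3)CC2)c2ccccc12` gives 1500 nM, compound 2 `Fc1cccc2c1ccn2CCCCN1CCN(C(c2ccccc2)c2ccccc2)CC1` gives 150 nM, and compound 3 `Fc1cc2ccn(CCCCN3CCN(C(c4ccccc4)c4ccccc4)CC3)c2cc1F` gives 130 nM. Compound 3 has the lowest of the three numbers, but its separation from compound 2 is only a 1.2-fold lower number from compound 2 to compound 3 (0.06 log units; within the scatter), so the two cannot be ranked; against compound 1 the separation is a 12-fold lower number from compound 1 to compound 3 (1.06 log units; beyond the scatter).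

Compound 4 `c1ccc(-c2nnnn2CCCCN2CCN(C(c3ccccc3)c3ccccc3)CC2)cc1` differs from compound 3 in one place: a group of 11 heavy atoms (7 carbon, 4 nitrogen; one five-membered aromatic ring with 4 hetero atoms, one six-membered aromatic ring of carbon only) in place of a group of 11 heavy atoms (8 carbon, 1 nitrogen, 2 fluorine; one five-membered aromatic ring with 1 hetero atom, one six-membered aromatic ring of carbon only), on a saturated chain carbon, four bonds along the chain from an amine nitrogen in a ring. The measured steps that bear on this are the exchanges of the whole bicyclic group on the same chain carbon: a 10-fold lower number from compound 1 to compound 2 (1.00 log units; beyond the scatter) and a 12-fold lower number from compound 1 to compound 3 (1.06 log units; beyond the scatter), both well beyond the scatter, while a 1.2-fold lower number from compound 2 to compound 3 (0.06 log units; within the scatter) shows that the two fluorinated variants are indistinguishable. The series thus shows that changing the group at this position can move the number well beyond the scatter. Among the compounds with values here, no measured compound carries a five-membered ring with four hetero atoms here, so the direction for compound 4 is not fixed by the data. With compound 1 at 1500 nM and compound 3 at 130 nM as the bracket seen so far, compound 4 is expected to land between them, which would mean a step of a 3.8-fold higher number from compound 3 to compound 4 (0.59 log units; beyond the scatter). The estimate for compound 4 in this assay is 500 nM, with a range from 100 nM to 3000 nM.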

Compound 4, half-maximal inhibitory concentration: 3200 nM
For compound 4 the middle estimate is 6.4-fold (0.81 log units) below the measured one; the whole stated range lies below it.
By their numbers in this assay, from the lowest: compounds 3 and 2 (each within the scatter of the next); then compound 1; then compound 4.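

The tetrazole result extends the top of the range at this position in this assay: the exchange gives a 25-fold higher number from compound 3 to compound 4 (1.39 log units; beyond the scatter) and a 21-fold higher number from compound 2 to compound 4 (1.33 log units; beyond the scatter) as well, so compound 4 has the highest number of the four and the weakest inhibition in the set. Compound 1 no longer marks the upper end of the series, since a 2.1-fold higher number from compound 1 to compound 4 (0.33 log units; beyond the scatter) is also beyond the scatter, and the change to 5-phenyl-1H-tetrazol-1-yl therefore moves the number further up than the nitrile-bearing group does. Heavy-atom count alone does not set the number here, since the group that leaves compound 3 and the one that enters compound 4 have the same count, and no measurement is at hand that accounts for the rise.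

Compound 4 alone carries the tetrazole, so the contributions of that ring and of its phenyl substituent cannot be separated from these compounds. On these data alone, it also remains open how a methyl in place of that phenyl, or a carboxylic acid or an amine on the phenyl, would read in this assay on the same saturated chain carbon.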